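Propyl in Place of Hydrogen on the Sulfonyl Chain

A few compounds are considered here, and "the series" means these few. Any claim that something is new, unique, unknown or untested is made for them only; others in the source may bear on it.

Compound 1, `CCCS(=O)(=O)Nc1ccc(F)c(C(=O)c2n[nH]c3ncc(-c4ccc(S(N)(=O)=O)cc4)cc23)c1F`, in an assay for binding affinity to dual specificity mitogen-activated protein kinase kinase 4 (Homo sapiens), read by KINOMEscan, tested at 100 nM; on this read-out lower numbers stand for a stronger effect and higher numbers for a weaker effect at the one concentration tested: 0.25%
Compound 2, `CS(=O)(=O)Nc1ccc(F)c(C(=O)c2n[nH]c3ncc(-c4ccc(S(N)(=O)=O)cc4)cc23)c1F`, in this assay: 0.6%

Compound 2 gives the higher of the two numbers, yet the step of a number 0.4 percentage points higher from compound 1 to compound 2 (within the scatter) lies within the scatter, so the two are not told apart. Compound 3, `CCCCS(=O)(=O)Nc1ccc(F)c(C(=O)c2n[nH]c3ncc(-c4ccc(S(N)(=O)=O)cc4)cc23)c1F`, differs from compound 2 by propyl in place of hydrogen on a saturated chain carbon bound to a sulfonyl sulfur. For the measured compounds named here, the only measured step that bears on this, a number 0.4 percentage points higher from compound 1 to compound 2 (within the scatter), is a change of the same kind in the other direction and stayed within the scatter. For compound 3 no step beyond the scatter is therefore expected, a number 0.2 percentage points lower from compound 2 to compound 3 (within the scatter). Compound 3 is estimated at 0.4%, between 0.1% and 2%.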

Compound 3, a percentage reported as activity, at one concentration (the size of the read-out at that concentration, not a potency): 0.25%
Compound 3: the middle estimate sits 0.2 percentage points above what was measured; measured number inside the range.
By their numbers in this assay, from the lowest: compounds 1, 3 and 2 (each within the scatter of the next).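

Going from methanesulfonamido to (butylsulfonyl)amino does not separate the compounds in this assay, with a number 0.4 percentage points lower from compound 2 to compound 3 (within the scatter) and no change at the digits printed from compound 1 to compound 3 (within the scatter) alongside. The methyl, propyl and butyl chains on the sulfonyl group therefore cannot be told apart here, and the comparison now reaches butyl, a longer chain than the first pair covered. Still open, on these data alone, is whether a longer chain, or an amine or a carboxylic acid at the end of the chain, would also leave this read-out within the scatter. Nothing available explains why these chains give such close numbers.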